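Aryl swap on the ring nitrogen: notes toward compound 3

The source may report more compounds than this note shows. Statements on the series, on what has been measured and on what is new or still open speak of the compounds shown alone.

Measured so far:
- In a functional assay on HT-29 cells (Homo sapiens) for cytotoxicity, read by MTT assay, with a stated time of 72 h (a higher number here means a weaker inhibitor, a lower number a stronger inhibitor), compound 1 `COc1cc2c(Oc3ccc(NC(=O)c4cn(-c5ccccc5F)nn4)cc3F)ccnc2cc1OCCCN1CCCCC1` gives 290 nM.
- In this assay compound 2 `COc1cc2c(Oc3ccc(NC(=O)c4cn(-c5ccc(Br)cc5)nn4)cc3F)ccnc2cc1OCCCN1CCCCC1` gives 260 nM.

Compound 2 stands at the lowest of the two numbers shown, though the step of a 1.1-fold lower number from compound 1 to compound 2 (0.05 log units; within the scatter) is within the scatter, so compound 1 and compound 2 are not separated. Compound 3 `COc1cc2c(Oc3ccc(NC(=O)c4cn(-c5ccc(F)c(F)c5)nn4)cc3F)ccnc2cc1OCCCN1CCCCC1` differs from compound 2 by 3,4-difluorophenyl in place of 4-bromophenyl on an aromatic nitrogen. Among the measured compounds shown here, the only measured step bearing on this change, another aryl swap on the same ring nitrogen, is a 1.1-fold lower number from compound 1 to compound 2 (0.05 log units; within the scatter), which was within the scatter. No step beyond the scatter is therefore expected in this assay, and the expected step of a 1.0-fold higher number from compound 2 to compound 3 (0.02 log units; within the scatter) is set accordingly. Compound 3 is estimated at 270 nM, with a range from 130 nM to 560 nM.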

Compound 3, half-maximal inhibitory concentration: 210 nM
Compound 3: the middle estimate sits 1.3-fold (0.11 log units) above what was measured; the measured number falls inside the stated range.
By their numbers in this assay, from the lowest: compounds 3, 2 and 1 (each within the scatter of the next).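

In this assay, a third aryl group on this ring nitrogen leaves the number unresolved: a 1.2-fold lower number from compound 2 to compound 3 (0.09 log units; within the scatter) and a 1.4-fold lower number from compound 1 to compound 3 (0.14 log units; within the scatter) both stay within the scatter. The position therefore accepts 3,4-difluorophenyl, with two fluorines on the aryl ring, without separating from 4-bromophenyl or 2-fluorophenyl, so no order among the three can be read.

Still open, as far as these compounds go, is whether a phenyl bearing an amine or a carboxylic acid, or a plain methyl or cyclohexyl in place of the aryl ring, would produce a step beyond the scatter. Nothing at hand accounts for the flat response at this position.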